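The source may hold more compounds than are shown below. What is called first, only, known or untested is meant among the compounds shown, and "the series" means these compounds.

Among the compounds with values here, compound 1 `CC(=O)N1N=C(c2ccc(OCc3cn(Cc4ccc([N+](=O)[O-])cc4)nn3)cc2)CC1c1ccccc1` is one of two compounds measured in a functional assay on A549 cells (Homo sapiens) for inhibition, read by sulforhodamine B assay, tested at 10 uM (on this read-out higher numbers stand for more inhibition of growth at the one concentration tested and lower numbers for less inhibition of growth), where compound 1 gives 15%. This is the lowest of the two numbers. The other measured compound is compound 2 `COc1cc(C2CC(c3cc(OC)c(OC)c(OC)c3)=NN2C(C)=O)ccc1OCc1cn(Cc2ccc([N+](=O)[O-])cc2)nn1`, which in this assay gives 68%; the gap between these two values is larger than the usual scatter, so compound 2 inhibits growth more strongly than compound 1.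

Compound 3 `COc1ccc(C2CC(c3ccc(OCc4cn(Cc5ccc([N+](=O)[O-])cc5)nn4)cc3)=NN2C(C)=O)cc1OC` has not yet been measured. It differs from compound 1 in one place: 3,4-dimethoxyphenyl in place of phenyl on a saturated ring carbon. The compound with methoxy groups on its aromatic rings, compound 2, shows the higher number, and compound 3 carries two such groups, so a rise beyond the scatter is expected for the step of a number 25 percentage points higher from compound 1 to compound 3 (beyond the scatter). The estimate for compound 3 in this assay is therefore 40%, with a range from 15% to 65%.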

Compound 3, percent growth inhibition at one concentration: 11%
Compound 3: middle estimate off by 29 percentage points, on the high side, and the stated range ends above it.
By their numbers in this assay, from the lowest: compounds 3 and 1 (each within the scatter of the next); then compound 2.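

In this assay, 3,4-dimethoxyphenyl in place of phenyl on this saturated ring carbon gives a number 4 percentage points lower from compound 1 to compound 3 (within the scatter). At this position, then, the change leaves the read-out where it was, and adding these two methoxy groups to the core of compound 1 does not reproduce the much higher number seen for compound 2, which differs from compound 1 in more than one place. Nothing available gives a reason for this flat step.

Which of the several differences in compound 2 goes with its higher number remains open, since no single step isolates any of them. Also open, from the compounds shown here alone, is whether a different kind of group on this phenyl ring, such as an amine or a carboxylic acid, would move the number at all.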